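The source may hold more compounds than are shown below. What is called first, only, known or untested is meant among the compounds shown, and "the series" means these compounds.

In a functional assay on the whole organism for inhibition, with Mus musculus as the target, in the maximal electroshock model, at a dose of 7.5 mg/kg by the oral route (a lower number here means a weaker effect, a higher number a stronger effect of the compound at the dose given), the three measured compounds stand as follows:

compound 1 `CN1C(=O)NC2(CC2(C)C)C1=O`: 40%
compound 2 `CCC(CO)N1C(=O)NC2(CC2(C)C)C1=O`: 30%
compound 3 `CC1(C)CC12NC(=O)N(c1ccccc1)C2=O`: 20%

Compound 3 holds the lowest of the three numbers, but compound 2 lies within the usual scatter of it, so no order between those two can be claimed; compound 1 stands beyond the scatter above compound 3. The unmeasured compound 4 `CC1(C)CC12NC(=O)N(c1ccc(F)cc1)C2=O` differs from compound 3 in one place: fluoro in place of hydrogen on an aromatic carbon. Going by the values given here, the only measured step, a number 10 percentage points lower from compound 1 to compound 2 (within the scatter), exchanges the group on the ring nitrogen and does not touch the aromatic ring, so it bears on this change only loosely; it shows that one exchange of a substituent left the read-out within the scatter. Among the compounds with values here, no measured pair shows what a fluoro on the aromatic ring does. The account therefore expects no change at the digits printed from compound 3 to compound 4 (within the scatter), a step not beyond the scatter. Compound 4 is estimated at 20%, between 5% and 40%.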

Compound 4, a percentage reported as inhibition, in the whole organism at one dose (the size of the read-out at that dose, not a potency): 30%
Estimate against measurement, compound 4: 10 percentage points below; measured number inside the range.
By their numbers in this assay, from the lowest: compounds 3, 2, 4 and 1 (each within the scatter of the next, the first and the last beyond it).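

In this assay, fluoro in place of hydrogen on an aromatic carbon, para to a large group, gives a number 10 percentage points higher from compound 3 to compound 4 (within the scatter), so this exchange leaves the effect at this dose within the scatter. Going by these compounds alone, the earlier compounds showed an exchange only on the ring nitrogen, whereas this step is the one measured change on the aromatic ring itself. Nothing available gives a reason for the size of this step.

As far as these compounds go, whether another group at this same place, such as chloro, methoxy or an amine, would carry the number beyond the scatter stays open, as does the effect of fluoro on another carbon of the aromatic ring. From the compounds shown here alone, the read-out also stands at a single dose, so whether compound 3 or compound 4 would have a stronger or weaker effect at any other dose remains unknown.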